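Benzyloxy in place of fluoro: working notes on compound 4

This account rests on a few compounds, and the source may have more. Where it says the series, first, only, none or still open, it means among the compounds named here.

Of the compounds shown here, three sharing one core have been measured in a functional assay on DU-145 cells (Homo sapiens) for inhibition, read by trypan blue exclusion, with a stated time of 96 h; on this read-out lower numbers stand for stronger inhibition of growth and higher numbers for weaker inhibition of growth. Compound 1 `Cc1ccc(C)c(/C=C(\C(=O)c2ccc(Cl)cc2)S(=O)(=O)c2ccc(Br)cc2)c1` gives 1000 nM, compound 2 `O=C(/C(=C\c1ccccc1F)S(=O)(=O)c1ccc(Br)cc1)c1ccc(Cl)cc1` gives 25000 nM and compound 3 `COc1ccc(/C=C(\C(=O)c2ccc(Cl)cc2)S(=O)(=O)c2ccc(Br)cc2)cc1O` gives 10000 nM. Compound 2 has the highest number of the three, and so the weakest inhibition of growth in this small set.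

Compound 4 `O=C(/C(=C\c1ccccc1OCc1ccccc1)S(=O)(=O)c1ccc(Br)cc1)c1ccc(Cl)cc1` departs from compound 2 in one place: benzyloxy in place of fluoro on an aromatic carbon. This is benzyloxy in place of fluoro on an aromatic carbon, ortho to a large group.

Among the compounds with values here, three measured steps bear on this change, all of them swaps of the aryl group on the double-bonded chain carbon. The large 25-fold higher number from compound 1 to compound 2 (1.40 log units; beyond the scatter) and the modest 10-fold higher number from compound 1 to compound 3 (1.00 log units; beyond the scatter) both lead away from compound 1, while the modest 2.5-fold lower number from compound 2 to compound 3 (0.40 log units; beyond the scatter) shows a second aryl group doing better than 2-fluorophenyl. Within the data shown here, no measured compound carries benzyloxy, so these steps give only a rough scale. Compound 2 at 25000 nM sits at the top of the measured range, which favours a move downward, though a rise cannot be excluded.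

A modest change is expected, namely a 4.2-fold lower number from compound 2 to compound 4 (0.62 log units; beyond the scatter). For compound 4 the estimated value is 6000 nM, with an expected range of 1000 nM to 30000 nM.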

Compound 4, concentration for 50% growth inhibition: 1000 nM
Beside the measured number, compound 4's estimate is 6.0-fold (0.78 log units) above it; measured number inside the range.
By their numbers in this assay, from the lowest: compounds 1 and 4 (each within the scatter of the next); then compound 3; then compound 2.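

In this assay the step of a 25-fold lower number from compound 2 to compound 4 (1.40 log units; beyond the scatter) shows that this aromatic carbon, ortho to a large group, accepts far more than fluoro: benzyloxy brings 8 heavy atoms and a six-membered aromatic ring of carbon only in place of 1 heavy atom, and the number falls. The earlier steps shown here exchanged whole aryl groups, whereas here one substituent alone changes, and compound 4 at 1000 nM lies within the scatter of compound 1 at 1000 nM even though the two carry different aryl groups on the shared core. Nothing shown here accounts for the size of this step.

Open, from the compounds shown here alone, is whether the step follows the oxygen, the added ring or the added atoms alone; an ethoxy group, a benzylamino group or a longer phenylalkoxy chain on this carbon would separate these. Also open, going by these compounds, is whether benzyloxy on another carbon of the same ring would give a step of similar size.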